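A few compounds are considered here, and "the series" means these few. Any claim that something is new, unique, unknown or untested is made for them only; others in the source may bear on it.

For the measured compounds named here, compound 2 `Cc1ccc2nc(N3CCCc4ccc(F)cc4C3)cc(NCCN3CCCCC3)c2c1` carries a 2-(piperidin-1-yl)ethyl group on a nitrogen on an aromatic ring of the shared core; in an ADME assay on HEp-2 cells (Homo sapiens) for cytotoxicity, read by CCK-8 assay, with a stated time of 5 days (on this read-out higher numbers stand for lower toxicity in this test and lower numbers for higher toxicity in this test), compound 2 gives 22000 nM, the lower of the two numbers measured so far. Going by the values given here, its only measured neighbour, compound 1 `Cc1ccc2nc(N3CCCc4ccc(F)cc4C3)cc(NCC(C)N)c2c1`, bears a 1-aminoethyl group at that place, and in this assay compound 1 gives 86000 nM. Among the compounds with values here, the step of a 3.9-fold lower number from compound 1 to compound 2 (0.59 log units; beyond the scatter) is the single measured step that bears on the present change. Compound 3 `Cc1ccc2nc(N3CCCc4ccc(F)cc4C3)cc(NC3(CN)COC3)c2c1`, not yet measured, differs from compound 2 by 3-(aminomethyl)oxetan-3-yl in place of 2-(piperidin-1-yl)ethyl on a nitrogen on an aromatic ring. The entering group brings back an aminomethyl arm, like the 1-aminoethyl of compound 1, so the reverse of that measured step is the nearest guide, though the oxetane ring resembles nothing measured. Compound 3 is therefore expected to show a higher number in this assay, estimated at 55000 nM (range 20000 nM to 160000 nM). This estimate means a step of a 2.5-fold higher number from compound 2 to compound 3 (0.40 log units; beyond the scatter) is expected.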

Compound 3, half-maximal cytotoxic concentration: 86000 nM
For compound 3 the middle estimate is 1.6-fold (0.19 log units) below the measured one, within the range that was stated.
By their numbers in this assay, from the lowest: compound 2; then compounds 1 and 3 (each within the scatter of the next).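

In this assay, 3-(aminomethyl)oxetan-3-yl in place of 2-(piperidin-1-yl)ethyl on the nitrogen gives a 3.9-fold higher number from compound 2 to compound 3 (0.59 log units; beyond the scatter), so compound 2 is no longer set apart from a single neighbour only: two different groups at this place now read higher than it does. Setting 3-(aminomethyl)oxetan-3-yl in place of 2-aminopropyl gives no change at the digits printed from compound 1 to compound 3 (within the scatter), which shows that the four-membered ring with its oxygen makes no readable difference to the number here. Nothing shown explains either result.

The compounds shown leave open whether the lower number of compound 2 goes with its piperidine ring or with the loss of the free amine. A 2-(morpholin-4-yl)ethyl or 2-(dimethylamino)ethyl group at this nitrogen could separate those two readings.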